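Swapping Chloro for Fluoro on the Benzyl Ring

The compounds below may be only part of what the source reports. "The series", "measured", "known", "first", "only" and "open" are said of these compounds alone.

Of the compounds shown here, three have been measured in a functional assay on the whole organism (artery, strain albino) with Rattus norvegicus as the target, with a stated time of 360 min, at a dose of 10 mg/kg by the oral route; on this read-out higher numbers stand for more inhibition at the one dose given (going by the name of the read-out) and lower numbers for less inhibition. Compound 1, `COc1ccc(C2N=C(SCc3ccc(Cl)cc3)NC(C)=C2C(=O)Nc2ccc(F)cc2)cc1OC`, gives 37.1% in this assay. Compound 2, `COc1ccc(C2N=C(SCc3ccc(F)cc3)NC(C)=C2C(=O)Nc2ccc(F)cc2)cc1OC`, gives 37.1%. These two differ in one spot: fluoro in place of chloro on an aromatic carbon. On this read-out no change at the digits printed from compound 1 to compound 2 (within the scatter). Compound 3, `CC1=C(C(=O)Nc2ccc(Br)cc2)C(c2ccc(Cl)cc2Cl)N=C(SCc2ccc(Cl)cc2)N1`, gives 39.7% in this assay; its number lies within the scatter of the numbers for compound 1 and compound 2, so no order among the three can be claimed. How the core of compound 3 differs from the core of compound 1 is not broken down here.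

Compound 4, `CC1=C(C(=O)Nc2ccc(Br)cc2)C(c2ccc(Cl)cc2Cl)N=C(SCc2ccc(F)cc2)N1`, has not yet been measured. It relates to compound 3 exactly as compound 2 relates to compound 1: fluoro in place of chloro on an aromatic carbon. The surroundings of the changed spot read the same for both pairs, so this is the same change. Because no change at the digits printed from compound 1 to compound 2 (within the scatter) stayed within the scatter, compound 4 is expected to show a step of similar size, namely no change at the digits printed from compound 3 to compound 4 (within the scatter). Compound 4 is therefore estimated to give 39.7% in this assay, with the expected range running from 28% to 51%.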

Compound 4, a percentage reported as inhibition, in the whole organism at one dose (the size of the read-out at that dose, not a potency): 40.7%
Estimate against measurement, compound 4: 1 percentage points below; low and high end bracket the measured number.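

In this assay, the swap from 4-chlorobenzyl to 4-fluorobenzyl on the second core gives a small step, a number 1 percentage points higher from compound 3 to compound 4 (within the scatter). Set beside the earlier pair, the change reads alike on both cores: the same change on two cores in this assay, no change at the digits printed (within the scatter) from compound 1 to compound 2 and a number 1 percentage points higher (within the scatter) from compound 3 to compound 4, 1 percentage points apart, within the scatter of two such steps

This shows that, on these two cores, chloro and fluoro at this spot can be exchanged without a step that stands out from the scatter, but it does not show that the same would hold on a third core, or at another dose, and two pairs cannot explain why the two groups read alike.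

As far as these compounds go, only chloro and fluoro appear at this spot, so what a methoxy group, an amine or a carboxylic acid would do there remains open. Also open, from the compounds shown here alone, is whether a plain methyl or a longer alkyl chain in place of the whole 4-fluorobenzyl group would keep the number in the same range.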